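The source may hold more compounds than are shown below. What is called first, only, known or untested is meant among the compounds shown, and "the series" means these compounds.

In a functional assay on BeWo cells (Homo sapiens) for inhibition, read by MTT assay, with a stated time of 72 h (a higher number here means a weaker inhibitor, a lower number a stronger inhibitor), compound 1 (`CCC(=O)N1CCN(c2nnc3nncn3n2)CC1`) gives 13700 nM while compound 2 (`CCCNc1nnc2nncn2n1`) gives 14300 nM and compound 3 (`CCCCNc1nnc2nncn2n1`) gives 8640 nM on the same read-out. All three values lie within the usual scatter of one another, so compound 1 holds no distinct rank among them. The change to compound 4 (`CCCCC(=O)N1CCN(c2nnc3nncn3n2)CC1`) turns propanoyl into butylcarbonyl, with ethyl in place of hydrogen on a saturated chain carbon, two bonds along the chain from a carbonyl carbon. Among the measured compounds shown here, only one measured step bears on this, and only indirectly. The step of a 1.7-fold lower number from compound 2 to compound 3 (0.22 log units; within the scatter) also lengthens a chain, but it adds methyl rather than ethyl, and it does so three bonds along the chain from a nitrogen on an aromatic ring. For the measured compounds named here, no measured pair carries a change on the carbonyl side of the shared core. A small drift toward a lower number is possible, but no step beyond the scatter is expected in this assay. The expected step is a 1.4-fold lower number from compound 1 to compound 4 (0.14 log units; within the scatter) and it is estimated to remain within the scatter. For compound 4 an estimate of 10000 nM is expected, with 5000 nM to 20000 nM as the likely span.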

Compound 4, half-maximal inhibitory concentration: 1720 nM
The estimate for compound 4 lay 5.8-fold (0.76 log units) above the measured number; measured number outside the range, below it.
By their numbers in this assay, from the lowest: compound 4; then compounds 3, 1 and 2 (each within the scatter of the next).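

In this assay, ethyl in place of hydrogen on a saturated chain carbon, two bonds along the chain from a carbonyl carbon, gives an 8.0-fold lower number from compound 1 to compound 4 (0.90 log units; beyond the scatter), the first step beyond the scatter among the compounds shown. The only earlier chain extension, a 1.7-fold lower number from compound 2 to compound 3 (0.22 log units; within the scatter), gave no such separation, but it was a different change at a different place, so it said nothing about this position. The propanoyl to butylcarbonyl change therefore marks this position as one where the number in this assay responds to chain length, although the data shown offer no measurement that accounts for the size of the step.

Whether the trend continues is open: a longer chain such as hexanoyl could extend the step, hold it or reverse it, and two chain lengths define no optimum. Also open, on these data alone, is whether this position requires a plain alkyl chain, or whether a branched isopropyl group, a phenyl ring, an amine or a carboxylic acid at the chain end would keep the lower number.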